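Swapping the ethoxycarbonyl group for a methylpyrazole

The source may report more compounds than this note shows. Statements on the series, on what has been measured and on what is new or still open speak of the compounds shown alone.

Compound 1 `Cc1cc(C#N)nc(NNC(=O)Nc2cc(Cl)nc(Cl)c2)c1`: in a functional assay on CHO cells for antagonist activity at sphingosine 1-phosphate receptor 2 (Homo sapiens), read by fluorescence and calcium flux, with a stated time of 3 min (on this read-out lower numbers stand for stronger inhibition and higher numbers for weaker inhibition), compound 1 reaches only the assay limit, > 6600 nM.
Compound 2 `Cc1cc(CO)nc(NNC(=O)Nc2cc(Cl)nc(Cl)c2)c1`: in this assay compound 2 likewise reaches only the limit, > 6600 nM.
Compound 3 `CCOC(=O)c1cc(C)cc(NNC(=O)Nc2cc(Cl)nc(Cl)c2)n1`: in this assay compound 3 gives 760 nM.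

Going by the values given here, compound 3 is the only compound of the three with a real number; the other two values are limits (the limit of > 6600 nM in this assay, at which 2 of the 3 values shown sit). The two steps that lead to it are both clear: an at least 8.6-fold lower number from compound 1 to compound 3 (0.93 log units; beyond the scatter) and an at least 8.6-fold lower number from compound 2 to compound 3 (0.93 log units; beyond the scatter). Whether compound 1 and compound 2 differ from one another cannot be read, since a step that the two limits leave unreadable from compound 1 to compound 2.

Compound 4 `Cc1cc(NNC(=O)Nc2cc(Cl)nc(Cl)c2)nc(-c2cnn(C)c2)c1` is not yet measured. It differs from compound 3 in one place: 1-methyl-1H-pyrazol-4-yl in place of ethoxycarbonyl on an aromatic carbon. No measured step covers this kind of change; the only steps shown tell that among cyano, hydroxymethyl and ethoxycarbonyl only the ethoxycarbonyl group gives a readable number. The pyrazole is a ring rather than an ester, so the measured steps do not point in a clear direction. Compound 4 is therefore expected to lose some of the activity of compound 3, with a 2.6-fold higher number from compound 3 to compound 4 (0.42 log units; beyond the scatter) as the estimated step. Compound 4 is estimated at 2000 nM, in the range 400 nM to 6600 nM.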

Compound 4, half-maximal inhibitory concentration: > 2100 nM
Compound 4 gave a limit, no number; the forecaster's own chance of this, stated with the estimate: 35%; at least 1.0-fold (0.02 log units) between middle value and limit.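

In this assay putting 1-methyl-1H-pyrazol-4-yl in place of ethoxycarbonyl next to the ring nitrogen gives an at least 2.7-fold higher number from compound 3 to compound 4 (0.44 log units; beyond the scatter) and so adds an aromatic ring to cyano and hydroxymethyl among the groups here that do not match the ester. The two groups carry the same counts of hydrogen-bond donors and acceptors and no net charge, so matching those counts alone does not keep the number of compound 3. Compound 4 gives only a limit, not a number: the limit of > 2100 nM in this assay, at which 1 of the 4 values shown sits.

Going by these compounds, the steps between compound 4 and compound 1 or compound 2 cannot be read, so the order of these three stays unknown. On these data alone, whether a carboxylic acid, a primary amide or a longer ester chain such as propoxycarbonyl at this place would hold or improve on compound 3 remains open.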